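This account rests on a few compounds, and the source may have more. Where it says the series, first, only, none or still open, it means among the compounds named here.

Compound 1 `COc1ccc([C@@H]2Oc3cc(OC)c(O)c(OC)c3C(=O)[C@@H]2O)cc1OC`: in a functional assay on PC-12 cells (Rattus norvegicus) for cytotoxicity, read by MTT assay, with stated times of 2 h and 4 h, tested at 32 ug/mL (a higher number here means a stronger effect of the compound at the concentration tested, a lower number a weaker effect), compound 1 gives 22%.
Compound 2 `COc1cc([C@@H]2Oc3cc(OC)c(O)c(OC)c3C(=O)[C@@H]2O)ccc1O`: in this assay compound 2 gives 1.6%.
Compound 3 `COc1ccc([C@@H]2Oc3cc(OC)c(OC)c(OC)c3C(=O)[C@@H]2O)cc1`: in this assay compound 3 gives 2.1%.

Compound 3 holds the second highest of the three numbers; compound 2 lies within the scatter of it, while compound 1 sits higher, beyond the scatter. Compound 4 `COc1ccc([C@@H]2Oc3cc(OC)c(OC)c(OC)c3C(=O)[C@@H]2O)cc1OC` has not yet been run in this assay. Its change from compound 3 is methoxy in place of hydrogen on an aromatic carbon. Among the measured compounds shown here, the one single-point step measured so far, a number 20.4 percentage points lower from compound 1 to compound 2 (beyond the scatter), concerns hydrogen in place of methyl on an oxygen on an aromatic ring and does not bear on methoxy in place of hydrogen. Compound 1 and compound 3 differ in two places, so their two values show only that the one carrying the extra methoxy is the higher. The step expected in this assay is therefore a number 5.9 percentage points higher from compound 3 to compound 4 (within the scatter), within the scatter. For compound 4 the estimate is 8%, expected between 1% and 22%.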

Compound 4, a percentage reported as activity, at one concentration (the size of the read-out at that concentration, not a potency): 2.4%
Compound 4: the middle estimate sits 5.6 percentage points above what was measured, and the stated range covers the measured number.
By their numbers in this assay, from the lowest: compounds 2, 3 and 4 (each within the scatter of the next); then compound 1.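

In this assay, methoxy in place of hydrogen, on an aromatic carbon ortho to a methoxy group and meta to a large group, gives a number 0.3 percentage points higher from compound 3 to compound 4 (within the scatter), so in this pair the added methoxy leaves the read-out unmoved. Methyl in place of hydrogen on the free aromatic hydroxyl gives a number 19.6 percentage points lower from compound 1 to compound 4 (beyond the scatter), which makes this oxygen a position where a single change does move the read-out. Nothing on hand gives a reason for either step.

As far as these compounds go, whether an amine or an ethoxy group at that oxygen would keep the number of compound 1 stays open. Also open, from the compounds shown here alone, is whether the added methoxy stays without effect when the hydroxyl is free.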